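Moving the furan attachment point on a shared core

A few compounds are considered here, and "the series" means these few. Any claim that something is new, unique, unknown or untested is made for them only; others in the source may bear on it.

Compound 1 `C[C@H]1[C@H](NCc2sccc2Br)C[C@H]2C[C@@H]1C2(C)C` and compound 2 `C[C@H]1[C@H](NCc2ccoc2)C[C@H]2C[C@@H]1C2(C)C` share the same core and differ only in the aromatic group on the saturated chain carbon bound to the amine nitrogen. In an ADME assay on MDCK cells (Canis lupus familiaris) for cytotoxicity, read by microscopy, with a stated time of 48 h (a higher number here means that more compound is tolerated, a lower number that less compound is tolerated), compound 1 gives 50000 nM. In this assay compound 2 reaches only a limit, > 100000 nM, so for compound 2 a bound and no number is known. The step of an at least 2.0-fold higher number from compound 1 to compound 2 (0.30 log units; that floor lies within the scatter) is accordingly known only as a floor, and that floor lies within the scatter; it rests on (the limit of > 100000 nM in this assay, at which 1 of the 2 values shown sits).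

Compound 3 `C[C@H]1[C@H](NCc2ccco2)C[C@H]2C[C@@H]1C2(C)C` has not yet been measured. Its difference from compound 2 is furan-2-yl in place of furan-3-yl on a saturated chain carbon bound to an amine nitrogen, the same atoms joined differently. Among the measured compounds shown here, the only measured step, from compound 1 to compound 2, exchanges one five-membered aromatic ring with 1 hetero atom for another and does not bear directly on moving the attachment point within the furan. For the measured compounds named here, no measured step shows an effect of such a change, so no step beyond the scatter is expected, and a number no higher from compound 2 to compound 3 (the limit leaves the size open) is the expected change. Compound 3 is therefore estimated at 100000 nM, within a range from 50000 nM to 200000 nM, and is expected most likely to sit again at the limit of this assay.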

Compound 3, minimum cytotoxic concentration: 50000 nM
The estimate for compound 3 lay 2.0-fold (0.30 log units) above the measured number, and the stated range covers the measured number.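

In this assay, among the compounds shown here, this pair gives the first reading on a change that keeps the same atoms and only joins them differently, on the saturated chain carbon bound to an amine nitrogen: the move within the furan gives an at least 2.0-fold lower number from compound 2 to compound 3 (0.30 log units; that floor lies within the scatter). Compound 2 stands at a limit of the assay, > 100000 nM, so this step is known only as a floor: the limit of > 100000 nM in this assay, at which 1 of the 3 values shown sits. The exchange of 3-bromothiophen-2-yl for furan-2-yl gives no change at the digits printed from compound 1 to compound 3 (within the scatter), which shows that a furan ring at this place does not by itself keep a compound at the limit, as compound 3 has a number where compound 2 has only a bound.

Going by these compounds, how far compound 2 and compound 3 truly lie apart stays open, and so does whether that gap goes beyond the scatter, since the floor alone cannot tell. Also open, on these data alone, is whether a phenyl ring or a pyridine ring on the same saturated chain carbon would read like compound 3 or reach a limit like compound 2.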